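Nitrofuran chalcone series: tolerance on Vero cells

The source may hold more compounds than are shown below. What is called first, only, known or untested is meant among the compounds shown, and "the series" means these compounds.

Measured so far:
compound 1, `COc1ccc(C(=O)/C=C/c2ccc([N+](=O)[O-])o2)cc1`, 571000 nM
compound 2, `COc1cc(C(=O)/C=C/c2ccc([N+](=O)[O-])o2)cc(OC)c1OC`, 384000 nM
compound 3, `O=C(/C=C/c1ccc([N+](=O)[O-])o1)c1cccs1`, 742000 nM

All three numbers come from a toxicity assay on Vero cells (Chlorocebus sabaeus) for cytotoxicity; a lower number here means that less compound is tolerated, a higher number that more compound is tolerated. Compound 1 sits in the middle of the three values; its gap to compound 3 and its gap to compound 2 both fall within the usual scatter of this assay, so the three compounds cannot be told apart on these numbers.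

Compound 4, `O=C(/C=C/c1ccc([N+](=O)[O-])o1)c1ccc(OCc2cccc(Cl)c2)cc1`, has not been measured. It differs from compound 1 in one place: 3-chlorophenyl in place of hydrogen on a saturated chain carbon bound to an oxygen on an aromatic ring. Going by the values given here, no pair of measured compounds shows a step of this kind, so nothing tells how large such a change moves the number.

On the structural change alone, the step in this assay from compound 1 to compound 4 is expected to be modest and downward, a 2.3-fold lower number from compound 1 to compound 4 (0.36 log units; beyond the scatter), meaning somewhat less compound is tolerated. For compound 4 the estimated value is 250000 nM, with an expected range from 80000 nM to 600000 nM.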

Compound 4, half-maximal cytotoxic concentration: 307000 nM
Compound 4: middle estimate off by 1.2-fold (0.09 log units), on the low side, and the stated range covers the measured number.
By their numbers in this assay, from the lowest: compounds 4, 2, 1 and 3 (each within the scatter of the next, the first and the last beyond it).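

In this assay, going by these compounds alone, the first step at this position, methoxy to (3-chlorobenzyl)oxy, reads a 1.9-fold lower number from compound 1 to compound 4 (0.27 log units; within the scatter), so compound 4 cannot be told apart from compound 1. The earlier compounds shown here showed no step of any kind; this one shows that a 3-chlorophenyl on the saturated chain carbon bound to an oxygen on an aromatic ring leaves the number within the scatter of the methoxy parent. Nothing available bears on why the step has this size.

A single substituent at a single position does not show whether this holds for other groups at the same place. From the compounds shown here alone, whether an amine, a carboxylic acid or a longer alkyl chain in place of the 3-chlorophenyl would also stay within the scatter of compound 1 remains open.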